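This account rests on a few compounds, and the source may have more. Where it says the series, first, only, none or still open, it means among the compounds named here.

Compound 1 `CC(C)(C)C1=C(C(=O)O)N2C(=O)[C@H](CO)[C@H]2O1` sets the starting point. In an ADME assay, in phosphate buffer, at 28 degrees C, at pH 7.0 (a higher number here means that the compound lasts longer, a lower number that the compound disappears faster), compound 1 gives 5 h. Compound 2 `CC(C)(C)C1=C(C(=O)O)N2C(=O)[C@H](CN)[C@H]2O1` carries an amine where compound 1 carries a hydroxyl, and in this assay compound 2 gives 1.2 h, which is a 4.2-fold lower number from compound 1 to compound 2 (0.62 log units; beyond the scatter). Compound 3 `CC(=O)NC[C@H]1C(=O)N2C(C(=O)O)=C(C(C)(C)C)O[C@H]12` carries an acetamido group at the same place. For compound 3 this assay reports only a limit, < 3 h, so its true value is not pinned down. That leaves an at least 1.6-fold lower number from compound 1 to compound 3 (0.22 log units; that floor lies within the scatter) and a step that the limit leaves unreadable from compound 2 to compound 3; the limit is described as the limit of < 3 h in this assay, at which 1 of the 3 values shown sits.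

Compound 4 `CC(C)(C)C1=C(C(=O)O)N2C(=O)[C@H](CNC(=O)[C@H](N)c3ccccc3)[C@H]2O1` changes the acetamido group itself: amino(phenyl)methyl in place of methyl on a carbonyl carbon. Among the compounds with values here, none of the measured steps alters the carbonyl substituent in this way, and the one step that touches the amide, from compound 2 to compound 3, cannot be sized. The expectation for compound 4 in this assay therefore rests on compound 3 alone and is uncertain in direction, with a step that the limit leaves unreadable from compound 3 to compound 4 expected. Compound 4 is estimated at 1.5 h, within a range from 0.5 h to 4 h, and may again come back only as a limit.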

Compound 4, half-life: 2.2 h
Compound 4: middle estimate off by 1.5-fold (0.17 log units), on the low side; the measured number falls inside the stated range.
By their numbers in this assay, from the lowest: compounds 2 and 4 (each within the scatter of the next); then compound 1.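

The step from compound 3 to compound 4 cannot be read, because the value of compound 3 in this assay is only a limit: the limit of < 3 h in this assay, at which 1 of the 4 values shown sits.

The compounds shown leave open how far, and in which direction, amino(phenyl)methyl in place of methyl on a carbonyl carbon shifts the half-life.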